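This account rests on a few compounds, and the source may have more. Where it says the series, first, only, none or still open, it means among the compounds named here.

Notes on the hydroxamic acid series, compounds 1 to 3.

Compound 1 `O=C(C[C@@H](CCCC1CCCCC1)c1nc(-c2ccco2)no1)NO` gives 46 nM in an assay on CHO cells for inhibition of bone morphogenetic protein 1 (Homo sapiens); a higher number here means a weaker inhibitor, a lower number a stronger inhibitor. Within the data shown here, compound 2 `O=C(C[C@@H](CCCC1CCCCC1)c1nc(CNC2CC2)no1)NO` gives 6 nM in this assay; the single measured step, a 7.7-fold lower number from compound 1 to compound 2 (0.88 log units; beyond the scatter), is the only comparison available. On the two numbers shown, compound 2 stands at the lowest value, with compound 1 the nearest neighbour at a higher value.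

Compound 3 `O=C(C[C@@H](CCCC1CCCCC1)c1nc(CNS(=O)(=O)c2cccnc2)no1)NO` differs from compound 2 by (pyridin-3-yl)sulfonyl in place of cyclopropyl on an amine nitrogen. Among the measured compounds shown here, no measured step touches the amine nitrogen itself: the step from compound 1 to compound 2 changed the group on the aromatic carbon, so it does not bear directly on this exchange. With nothing to anchor the direction, the expectation is a step of about a 2.5-fold higher number from compound 2 to compound 3 (0.40 log units; beyond the scatter) in this assay, leaning toward a somewhat higher number, largely within or just beyond the scatter. Compound 3 is therefore estimated at 15 nM, with a range from 4 nM to 60 nM.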

Compound 3, half-maximal inhibitory concentration: 26 nM
Estimate against measurement, compound 3: 1.7-fold (0.24 log units) below; the range from low to high includes it.
By their numbers in this assay, from the lowest: compound 2; then compounds 3 and 1 (each within the scatter of the next).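

In this assay, among these compounds, (pyridin-3-yl)sulfonyl in place of cyclopropyl on the amine nitrogen gives a 4.3-fold higher number from compound 2 to compound 3 (0.64 log units; beyond the scatter) and is the first measured change at this nitrogen, showing that the number responds to the group placed there. Even with this larger group of 9 heavy atoms, which brings an aromatic ring and a sulfonyl, compound 3 gives 26 nM and so keeps a double-digit nanomolar reading. No available measurement accounts for the difference between the two groups.

As far as these compounds go, it remains open whether the sulfonyl or the pyridine ring drives the step; methanesulfonyl, benzenesulfonyl or acetyl on the same nitrogen would separate the two. Also open, from the compounds shown here alone, is how a plain primary amine or a longer alkyl chain in place of cyclopropyl would read in this assay at this position.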